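The source may report more compounds than this note shows. Statements on the series, on what has been measured and on what is new or still open speak of the compounds shown alone.

Measured so far:

- compound 1 `Cc1ccc(/C=C2\CN(C(=S)SCc3cn(Cc4ccccc4F)nn3)C/C(=C\c3ccc(C)cc3)C2=O)cc1`: in a functional assay on MDA-MB-231 cells (Homo sapiens) for cytotoxicity, read by MTT assay, with a stated time of 24 h (on this read-out higher numbers stand for weaker inhibition and lower numbers for stronger inhibition), compound 1 gives 91500 nM
- compound 2 `Cc1ccc(/C=C2\CN(Cc3cn(Cc4ccccc4Cl)nn3)C/C(=C\c3ccc(C)cc3)C2=O)cc1`: in this assay compound 2 gives 29000 nM
- compound 3 `COc1ccc(/C=C2\CN(Cc3cn(Cc4ccccc4Cl)nn3)C/C(=C\c3ccc(OC)cc3)C2=O)cc1`: in this assay compound 3 gives a limit of the assay, > 100000 nM the limit of > 100000 nM in this assay, at which 1 of the 3 values shown sits.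

Among the three compounds sharing the core of compound 2, compound 2 has the lowest of the two real numbers, and compound 1 sits at a clearly higher number, beyond the usual scatter. The value of compound 3 is a limit only. Among the measured compounds shown here, no single-point step between measured compounds is available.

Compound 4 `Cc1ccc(/C=C2\CN(Cc3cn(Cc4ccc(F)cc4)nn3)C/C(=C\c3ccc(C)cc3)C2=O)cc1` differs from compound 2 in one place: 4-fluorophenyl in place of 2-chlorophenyl on a saturated chain carbon bound to an aromatic nitrogen. The measured compounds give no comparison of this kind to lean on, so in this assay a step of modest size is expected, more likely toward a higher number than toward a lower one, and possibly within the scatter. The step from compound 2 to compound 4 is expected to be a 1.4-fold higher number from compound 2 to compound 4 (0.14 log units; within the scatter). Compound 4 is therefore estimated at 40000 nM, with a range from 15000 nM to 100000 nM.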

Compound 4, half-maximal inhibitory concentration: 26800 nM
Compound 4: middle estimate off by 1.5-fold (0.17 log units), on the high side; the range from low to high includes it.
By their numbers in this assay, from the lowest: compounds 4 and 2 (each within the scatter of the next); then compound 1. At a limit, above all of these: compound 3.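

In this assay, among the compounds shown here, this is the first direct comparison at this position: replacing 2-chlorobenzyl with 4-fluorobenzyl gives a 1.1-fold lower number from compound 2 to compound 4 (0.03 log units; within the scatter). For this one pair, then, the read-out does not register the change, even though the halogen and its place on the ring differ together, so the pair cannot separate those two changes. Nothing measured here offers a reason for this result.

Going by these compounds, it remains open whether a plain benzyl group, or a benzyl group carrying an amine or a carboxylic acid, would move the number beyond the scatter. Also open, on these data alone, is whether the same replacement would behave alike on the core of compound 3, whose value is only a limit.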